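Swapping the aryl amide for a cyclobutyl amide

The source may hold more compounds than are shown below. What is called first, only, known or untested is meant among the compounds shown, and "the series" means these compounds.

Measured compounds:
- Compound 1 `CCCC(=O)N1CCC(NS(=O)(=O)c2ccc(NC(=O)c3ccc(F)cc3)c3ccccc23)CC1` gives 59.5 nM in an in vitro functional assay on CHO/Galpha16 cells for antagonist activity at C-C chemokine receptor type 8 (Homo sapiens), read by FLIPR; a higher number here means a weaker inhibitor, a lower number a stronger inhibitor
- Compound 2 `CCCC(=O)N1CCC(NS(=O)(=O)c2ccc(NC(=O)c3ccc(CC)cc3)c3ccccc23)CC1` gives 10.8 nM in this assay
- Compound 3 `CCOC(=O)N1CCC(NS(=O)(=O)c2ccc(NC(=O)c3ccncc3)c3ccccc23)CC1` gives 100 nM in this assay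

Among these three, compound 2 has the lowest number in this assay and is therefore the strongest inhibitor of the set; compound 1 is its nearest neighbour and compound 3 the furthest. Going by the values given here, the only single-point step available is a 5.5-fold lower number from compound 1 to compound 2 (0.74 log units; beyond the scatter), a gain that comes from changing one group on the aromatic ring of the amide.

Compound 4 `CCCC(=O)N1CCC(NS(=O)(=O)c2ccc(NC(=O)C3CCC3)c3ccccc23)CC1` is the next compound to be measured. It keeps the shared core of compound 2 and changes only the amide end: cyclobutyl in place of 4-ethylphenyl on a carbonyl carbon.

Among the compounds with values here, no measured pair shows an aromatic ring leaving the carbonyl altogether, so the step from compound 1 to compound 2 bears on this change only indirectly: it shows that the group at that end of the molecule can move the number well beyond the scatter. Since the whole 4-ethylphenyl goes and a cyclobutyl arrives, a weakening beyond the scatter is the expected outcome for compound 4, with a step of a 4.6-fold higher number from compound 2 to compound 4 (0.67 log units; beyond the scatter). The estimated value for compound 4 in this assay is 50 nM, expected to fall between 15 nM and 200 nM.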

Compound 4, half-maximal inhibitory concentration: 57.9 nM
Compound 4: the middle estimate sits 1.2-fold (0.06 log units) below what was measured; the range from low to high includes it.
By their numbers in this assay, from the lowest: compound 2; then compounds 4, 1 and 3 (each within the scatter of the next).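

In this assay, the change at this carbonyl carbon gives a 5.4-fold higher number from compound 2 to compound 4 (0.73 log units; beyond the scatter), so the 4-ethylphenyl group outperforms a small non-aromatic carbon ring at this position. The other new comparison gives a 1.0-fold lower number from compound 1 to compound 4 (0.01 log units; within the scatter), so cyclobutyl and 4-fluorophenyl cannot be told apart here, and among these compounds having an aromatic ring on the carbonyl does not by itself bring a gain: the 4-fluorophenyl compound has one and the cyclobutyl compound does not, yet their numbers match, while only the 4-ethylphenyl compound stands apart. No measurement shown explains why these groups behave this way.

The compounds shown leave open whether the gain with 4-ethylphenyl depends on the aromatic ring or on the ethyl group it carries, a question that a 4-ethylcyclohexyl group on the same carbonyl carbon could help to settle. They also leave open how a larger ring such as cyclohexyl, or a cyclobutyl ring carrying an amine or a carboxylic acid, would compare at this position.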